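This account rests on a few compounds, and the source may have more. Where it says the series, first, only, none or still open, it means among the compounds named here.

Compound 3 `COc1cc2c(cc1OC)CN(S(=O)(=O)c1ccc(-n3cc(COc4ccccc4C)nn3)cc1)CC2` belongs to a set of three close relatives tested in an ADME assay on Vero cells (Chlorocebus sabaeus) for cytotoxicity, with a stated time of 4 days; a lower number here means a stronger inhibitor, a higher number a weaker inhibitor. Compound 3 gives > 50 ug/mL, which is a limit of the assay rather than a number. Compound 1 `COc1cc2c(cc1OC)CN(S(=O)(=O)c1ccc(-n3cc(COc4ccc([N+](=O)[O-])cc4)nn3)cc1)CC2` gives > 50 ug/mL, also a limit. Compound 2 `COc1cc2c(cc1OC)CN(S(=O)(=O)c1ccc(-n3cc(COc4ccc(C)cc4)nn3)cc1)CC2` gives > 50 ug/mL, again a limit. All three sit at the limit of > 50 ug/mL in this assay, at which 3 of the 3 values shown sit. Compound 4 `COc1cc2c(cc1OC)CN(S(=O)(=O)c1ccc(-n3cc(COc4cc(C=O)ccc4OC)nn3)cc1)CC2` has not yet been measured; it differs from compound 3 by 5-formyl-2-methoxyphenyl in place of 2-methylphenyl on an oxygen on a saturated carbon. The measured steps a step that the two limits leave unreadable from compound 1 to compound 2, a step that the two limits leave unreadable from compound 1 to compound 3 and a step that the two limits leave unreadable from compound 2 to compound 3 cannot be read in size, so they give no direction. On that basis compound 4 is expected to show a step that the limit leaves unreadable from compound 3 to compound 4 in this assay, that is nothing beyond the scatter. Compound 4 is therefore estimated at 60 ug/mL, between 30 ug/mL and 120 ug/mL, most likely reported once more as a limit.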

Compound 4, half-maximal inhibitory concentration: > 50 ug/mL
Compound 4 was reported as a limit (the forecaster's own chance of this, stated with the estimate: 85%); the middle value lies beyond the limit too.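

The steps from compound 1, compound 2 and compound 3 to compound 4 cannot be read in size, since all four compounds give only a limit: the limit of > 50 ug/mL in this assay, at which 4 of the 4 values shown sit. The compounds shown leave open each compound's actual half-maximal inhibitory concentration, and whether swapping these groups changes it.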